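The source may report more compounds than this note shows. Statements on the series, on what has been measured and on what is new or still open speak of the compounds shown alone.

Measured compounds in a functional assay on CHO cells for agonist activity at metabotropic glutamate receptor 5 (Homo sapiens), read by inositol phosphate accumulation; a lower number here means a stronger inhibitor, a higher number a weaker inhibitor:
- compound 1, `COc1cccc(C#Cc2csc(C)n2)c1`, gives 49 nM
- compound 2, `COc1ccc(C#Cc2csc(C)n2)cn1`, gives 426 nM
- compound 3, `Cc1nc(C#Cc2cnccn2)cs1`, gives 1830 nM

Compound 1 has the lowest number of the three in this assay. Compound 2 stands nearest, with a higher number that lies beyond the usual scatter, and compound 3 stands furthest, also beyond the scatter. No two of these compounds differ in only one place, so no single counted step is available among them; each pair shows only what its two values show.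

Compound 4, `Cc1nc(C#Cc2cccc(O)c2)cs1`, has not yet been measured. It differs from compound 1 in one place: hydrogen in place of methyl on an oxygen on an aromatic ring. For the measured compounds named here, nothing among the measured compounds shows this kind of change, so the expectation rests on the value of compound 1 alone. The step from compound 1 to compound 4 is expected to be small, at most a modest weakening, and may fall within the scatter: a 2.4-fold higher number from compound 1 to compound 4 (0.39 log units; beyond the scatter). Compound 4 is therefore estimated at 120 nM, with a range from 40 nM to 400 nM, to be replaced by the measurement when it is known.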

Compound 4, half-maximal inhibitory concentration: 654 nM
Compound 4: middle estimate off by 5.5-fold (0.74 log units), on the low side; measured number above the stated range.
By their numbers in this assay, from the lowest: compound 1; then compounds 2 and 4 (each within the scatter of the next); then compound 3.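

In this assay, for the compounds shown here, the first single-place step is large: hydrogen in place of methyl on an oxygen on an aromatic ring gives a 13-fold higher number from compound 1 to compound 4 (1.13 log units; beyond the scatter). The value therefore depends strongly on this oxygen substituent, and losing one carbon is enough to change it well beyond the scatter. The data give no explanation for the size of this step.

As far as these compounds go, it remains open whether the methyl itself is what counts, since an ethyl group on the same oxygen, or an amine or a fluorine in place of the methoxy group, would test that directly. From the compounds shown here alone, it also remains open whether methoxy to hydroxy gives a step of this size on any other core.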